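The source may hold more compounds than are shown below. What is called first, only, known or untested is meant among the compounds shown, and "the series" means these compounds.

Measured so far:
- compound 1, `Cn1ncc2cc(-c3cnccc3/C=C/C(=O)N3CCOCC3)ccc21`: 356 nM
- compound 2, `O=C(/C=C/c1ccncc1-c1ccc2cc[nH]c2c1)N1CCOCC1`: 43.9 nM
- compound 3, `Cn1ncc2cc(-c3cnccc3/C=C/C(=O)O)ccc21`: 34.6 nM

All three were run in an assay on a protein complex for inhibition of CDK8/Cyclin C (Homo sapiens), with a stated time of 1 h; on this read-out lower numbers stand for stronger inhibition and higher numbers for weaker inhibition. The difference between the cores of compound 1 and compound 2 is not broken down here. Compound 3 carries the change hydroxy in place of morpholin-4-yl on a carbonyl carbon relative to compound 1, and that step, a 10-fold lower number from compound 1 to compound 3 (1.01 log units; beyond the scatter), is large. Compound 2 and compound 3 sit within the scatter of one another.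

Compound 4, `O=C(O)/C=C/c1ccncc1-c1ccc2cc[nH]c2c1`, remains unmeasured; it differs from compound 2 by hydroxy in place of morpholin-4-yl on a carbonyl carbon, the same change as from compound 1 to compound 3, on the same kind of carbonyl carbon. Going by the values given here, with only one such step on record, the expected step for compound 4 is taken as somewhat smaller than a 10-fold lower number from compound 1 to compound 3 (1.01 log units; beyond the scatter), namely a 5.5-fold lower number from compound 2 to compound 4 (0.74 log units; beyond the scatter). Compound 4 is therefore estimated at 8 nM in this assay, between 2 nM and 30 nM.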

Compound 4, half-maximal inhibitory concentration: 2.4 nM
The estimate for compound 4 lay 3.3-fold (0.52 log units) above the measured number; the range from low to high includes it.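

In this assay, the change from (morpholin-4-yl)carbonyl to carboxy carries over to the core of compound 2, giving an 18-fold lower number from compound 2 to compound 4 (1.26 log units; beyond the scatter). The two steps run the same way and do not differ in size beyond the scatter: the same change on two cores in this assay, a 10-fold lower number (1.01 log units; beyond the scatter) from compound 1 to compound 3 and an 18-fold lower number (1.26 log units; beyond the scatter) from compound 2 to compound 4, 1.8-fold (0.25 log units) apart, within the scatter of two such steps. This supports carrying the change across these two cores only; it does not show that the step holds on other cores or explain why it arises.

From the compounds shown here alone, how a methyl ester or a primary amide on the same carbonyl carbon would compare with carboxy remains open. Also open, going by these compounds, is whether a tetrazole in place of carboxy, or a longer chain bearing the carboxy, would keep the low numbers.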